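The source may hold more compounds than are shown below. What is called first, only, known or untested is meant among the compounds shown, and "the series" means these compounds.

Values in a functional assay on DU-145 cells (Homo sapiens) for inhibition, read by trypan blue exclusion, with a stated time of 96 h; on this read-out lower numbers stand for stronger inhibition of growth and higher numbers for weaker inhibition of growth:
- compound 1 `COc1ccc(S/C(=C/c2ccc(Cl)cc2Cl)C(=O)c2ccc(Br)cc2)cc1`: 1000 nM
- compound 2 `Nc1c(Br)cc(Br)cc1/C=C(/Sc1ccc(Br)cc1)C(=O)c1ccc(Br)cc1`: > 100000 nM (a limit)
- compound 3 `O=C(/C(=C\c1ccc(I)cc1)Sc1ccc(Br)cc1)c1ccc(Br)cc1`: 1000 nM

Compound 3 at 1000 nM stands level with compound 1. Compound 2 gives > 100000 nM, which is a limit of the assay. Compound 4 `O=C(/C(=C\c1ccc(Cl)cc1Cl)Sc1ccc(Br)cc1)c1ccc(Br)cc1` carries 2,4-dichlorophenyl in place of 4-iodophenyl on a double-bonded chain carbon bound to a double-bonded chain carbon. Within the data shown here, the one measured step at this place, an at least 100-fold lower number from compound 2 to compound 3 (2.00 log units; beyond the scatter), is large, but it starts from the limit of > 100000 nM in this assay, at which 1 of the 3 values shown sits, and involves a different leaving group, so it says little about this swap. Compound 1 also carries 2,4-dichlorophenyl and gives 1000 nM. In this assay, no step beyond the scatter is therefore expected: no change at the digits printed from compound 3 to compound 4 (within the scatter). The estimate for compound 4 is 1000 nM, with an expected range of 300 nM to 4000 nM.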

Compound 4, concentration for 50% growth inhibition: 1000 nM
Estimate against measurement, compound 4: no gap at the digits printed; the measured number falls inside the stated range.
By their numbers in this assay, from the lowest: compounds 1, 3 and 4 (each within the scatter of the next). At a limit, above all of these: compound 2.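

In this assay, 2,4-dichlorophenyl and 4-iodophenyl on a double-bonded chain carbon bound to a double-bonded chain carbon cannot be told apart: no change at the digits printed from compound 3 to compound 4 (within the scatter). With 2,4-dichlorophenyl held fixed, bromo in place of methoxy on an aromatic carbon also leaves the number unmoved: no change at the digits printed from compound 1 to compound 4 (within the scatter). The large step away from 2-amino-3,5-dibromophenyl recurs with a second group, an at least 100-fold lower number from compound 2 to compound 4 (2.00 log units; beyond the scatter), but compound 2 stands at a limit, not a number: the limit of > 100000 nM in this assay, at which 1 of the 4 values shown sits.

From the compounds shown here alone, whether an amine or a carboxylic acid in place of these halogens would shift the number stays open. Also open, going by these compounds, is how the large step divides between the amino and bromo substituents of 2-amino-3,5-dibromophenyl.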